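Butyl in place of furan-2-yl on the shared core

The source may report more compounds than this note shows. Statements on the series, on what has been measured and on what is new or still open speak of the compounds shown alone.

In a functional assay on cells (Platelet, Homo sapiens) for inhibition (a higher number here means a weaker inhibitor, a lower number a stronger inhibitor), compound 1 `CCOC(=O)c1ccc(-c2nn(Cc3ccccc3Cl)c3ccccc23)cc1` gives 230 nM. Going by the values given here, compound 2 `CCOC(=O)c1ccc(-c2nn(-c3ccco3)c3ccccc23)cc1` gives 340 nM, so the two numbers available so far lie within the scatter of each other and do not separate compound 2 from compound 1.

Compound 3 `CCCCn1nc(-c2ccc(C(=O)OCC)cc2)c2ccccc21` has yet to be measured. It differs from compound 2 on an aromatic nitrogen, with butyl in place of furan-2-yl on an aromatic nitrogen.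

Among the compounds with values here, one measured step bears on this place, a 1.5-fold higher number from compound 1 to compound 2 (0.17 log units; within the scatter), with furan-2-yl in place of 2-chlorobenzyl. That step is small and within the scatter. Within the data shown here, both groups in it contain a ring and butyl has none, so the series holds no measured example of a group without a ring here, and the step sets no firm direction. No step beyond the scatter is expected, though the range must stay wide.

The expected step is a 1.2-fold higher number from compound 2 to compound 3 (0.07 log units; within the scatter). In this assay the estimate for compound 3 is 400 nM, with an expected range of 130 nM to 1200 nM.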

Compound 3, half-maximal inhibitory concentration: 670 nM
Compound 3: the middle estimate sits 1.7-fold (0.22 log units) below what was measured; low and high end bracket the measured number.
By their numbers in this assay, from the lowest: compounds 1, 2 and 3 (each within the scatter of the next, the first and the last beyond it).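

In this assay, going by these compounds alone, butyl is the only group on the aromatic nitrogen without a ring, and a 2.0-fold higher number from compound 2 to compound 3 (0.29 log units; within the scatter) keeps it within the scatter of furan-2-yl, so losing the ring of furan-2-yl does not separate these two compounds. Within the data shown here, the comparison with 2-chlorobenzyl reads differently: a 2.9-fold higher number from compound 1 to compound 3 (0.46 log units; beyond the scatter) with propyl in place of 2-chlorophenyl on the saturated chain carbon bound to the aromatic nitrogen, the only step that is beyond the scatter, though it is modest. No supporting measurement accounts for either step.

On these data alone, it remains open whether a longer chain such as hexyl, or a butyl chain ending in an amine or a carboxylic acid, would fall nearer compound 1 or compound 3 at this nitrogen. All three compounds also carry the same ethyl ester, so the series gives no reading of how a free carboxylic acid or an amide in its place would behave in this assay with any of these groups on the nitrogen.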